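A few compounds are considered here, and "the series" means these few. Any claim that something is new, unique, unknown or untested is made for them only; others in the source may bear on it.

- Compound 1 `O=C1NCCC12CCN(c1c(Cl)cncc1-c1cc[nH]c1)CC2`: 1050 nM
- Compound 2 `Cc1ccc(-c2cncc(Cl)c2N2CCC3(CCNC3=O)CC2)o1`: 4950 nM
- Compound 3 `O=Cc1ccc(-c2cncc(Cl)c2N2CCC3(CCNC3=O)CC2)o1`: 5190 nM

In a functional assay on MV4-11 cells (Homo sapiens) for inhibition, read by resazurin assay, with a stated time of 72 h (a lower number here means a stronger inhibitor of growth, a higher number a weaker inhibitor of growth), compound 1 gives the lowest of the three numbers, and its steps to the other two both lie beyond the scatter. That makes compound 1 the strongest growth inhibitor of this small set.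

Compound 4 `Cc1ccc(-c2cncc(Cl)c2N2CCC3(CCNC3=O)CC2)s1` has not yet been measured. It differs from compound 1 in a single group: 5-methylthiophen-2-yl in place of 1H-pyrrol-3-yl on an aromatic carbon. In words, 5-methylthiophen-2-yl stands in place of 1H-pyrrol-3-yl on an aromatic carbon.

Within the data shown here, no measured compound carries this new group, so the forecast has to lean on close relatives. The most relevant measurement is a 4.7-fold higher number from compound 1 to compound 2 (0.67 log units; beyond the scatter), which came from placing 5-methylfuran-2-yl at the same carbon. A second replacement, with 5-formylfuran-2-yl, gave a similar result: a 4.9-fold higher number from compound 1 to compound 3 (0.69 log units; beyond the scatter). Changing the group on the furan made no difference beyond the scatter: a 1.0-fold higher number from compound 2 to compound 3 (0.02 log units; within the scatter).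

Among the measured compounds shown here, both replacements moved the number upward by a modest amount, so a modest rise of similar size is expected here, although only two compounds support this. The estimated change is a 4.3-fold higher number from compound 1 to compound 4 (0.63 log units; beyond the scatter). For compound 4, the expected value is 4500 nM, with an estimated range of 1800 nM to 11000 nM.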

Compound 4, concentration for 50% growth inhibition: 650 nM
Compound 4: the middle estimate sits 6.9-fold (0.84 log units) above what was measured; the whole stated range lies above it.
By their numbers in this assay, from the lowest: compounds 4 and 1 (each within the scatter of the next); then compounds 2 and 3 (each within the scatter of the next).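

In this assay, the step to 5-methylthiophen-2-yl gives a 1.6-fold lower number from compound 1 to compound 4 (0.21 log units; within the scatter), so this carbon tolerates a group with no hydrogen-bond donor, and the rise seen with the two furans cannot be put down simply to losing the donor of 1H-pyrrol-3-yl. The ring itself now matters, as the thiophene and furan groups with the same methyl give a 7.6-fold lower number from compound 2 to compound 4 (0.88 log units; beyond the scatter), and the comparison with the formyl-bearing furan gives an 8.0-fold lower number from compound 3 to compound 4 (0.90 log units; beyond the scatter), although that step changes both the ring and the group on it. Nothing available here explains why the sulfur-containing ring performs differently from the oxygen-containing one.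

The compounds shown leave open what the methyl contributes on the thiophene, which an unsubstituted thiophen-2-yl group would help to settle, and how a 5-formylthiophen-2-yl group, or a thiophene carrying an amine or a carboxylic acid, would behave at this carbon. They also leave open whether the chloro group could be exchanged for a fluoro or a nitrile while keeping the 5-methylthiophen-2-yl group in place.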